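From 2-Acetylphenyl to 4-Chlorophenyl: An Expected Step

This account rests on a few compounds, and the source may have more. Where it says the series, first, only, none or still open, it means among the compounds named here.

Compound 1 `C=C1CCC[C@]2(C)CCC(c3cn(-c4ccc(C(C)=O)cc4)nn3)=CC[C@@]12C` at 520000 nM
Compound 2 `C=C1CCC[C@]2(C)CCC(c3cn(-c4ccc(I)cc4)nn3)=CC[C@@]12C` at 215000 nM
Compound 3 `C=C1CCC[C@]2(C)CCC(c3cn(-c4ccccc4C(C)=O)nn3)=CC[C@@]12C` at 524000 nM

In an ADME assay on HEK293 cells (Homo sapiens) for cytotoxicity, read by MTT assay, with a stated time of 48 h (a lower number here means a stronger inhibitor, a higher number a weaker inhibitor), compound 3 gives 524000 nM as its value. Moving the acetyl group brings no real change (a 1.0-fold higher number from compound 1 to compound 3 (0.00 log units; within the scatter)) while 2-acetylphenyl in place of 4-iodophenyl raises the number modestly (a 2.4-fold higher number from compound 2 to compound 3 (0.39 log units; beyond the scatter)). Compound 4 `C=C1CCC[C@]2(C)CCC(c3cn(-c4ccc(Cl)cc4)nn3)=CC[C@@]12C` carries 4-chlorophenyl in place of 2-acetylphenyl on an aromatic nitrogen. Within the data shown here, no chloro compound has been measured yet, so the nearest guide is iodo in place of acetyl (a 2.4-fold lower number from compound 1 to compound 2 (0.38 log units; beyond the scatter)). A modest fall of similar size is therefore expected in this assay overall. The estimated step is a 2.2-fold lower number from compound 3 to compound 4 (0.34 log units; beyond the scatter) in size. Compound 4 is estimated at 240000 nM within a range of 110000 nM to 500000 nM overall.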

Compound 4, half-maximal inhibitory concentration: 609000 nM
Beside the measured number, compound 4's estimate is 2.5-fold (0.40 log units) below it, and the stated range ends below it.
By their numbers in this assay, from the lowest: compound 2; then compounds 1, 3 and 4 (each within the scatter of the next).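

In this assay, chloro does not behave like iodo: chloro in place of iodo gives a 2.8-fold higher number from compound 2 to compound 4 (0.45 log units; beyond the scatter), while chloro in place of acetyl gives a 1.2-fold higher number from compound 1 to compound 4 (0.07 log units; within the scatter), and 4-chlorophenyl in place of 2-acetylphenyl gives a 1.2-fold higher number from compound 3 to compound 4 (0.07 log units; within the scatter). So a halogen on this phenyl ring does not by itself lower the number, and of these four compounds only compound 2 stands apart. Nothing measured here explains the difference between iodo and chloro. On these data alone, whether bromo would side with iodo or with chloro stays open. So does the effect of an amine or a carboxylic acid on this ring.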